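The source may hold more compounds than are shown below. What is called first, only, known or untested is meant among the compounds shown, and "the series" means these compounds.

Compound 3 `CS(=O)(=O)c1cnc(O[C@H]2CC[C@H](OC3CCN(C(=O)Oc4ccccc4)CC3)CC2)cn1` gives in a functional assay on isolated protein for agonist activity at Glucose-dependent insulinotropic receptor (Rattus norvegicus), read by HTRF and cAMP accumulation (a higher number here means that more compound is needed for the effect, a lower number that less compound is needed), 71.8 nM, the lowest number of the three measured compounds, though compound 1 `CC1(OC(=O)N2CCC(O[C@H]3CC[C@H](Oc4cnc(S(C)(=O)=O)cn4)CC3)CC2)CC1` with 138 nM sits within the scatter of it; compound 2 `C[C@H](CF)OC(=O)N1CCC(O[C@H]2CC[C@H](Oc3cnc(S(C)(=O)=O)cn3)CC2)CC1` gives 317 nM. The measured steps all exchange the group on the carbamate oxygen: a 1.9-fold lower number from compound 1 to compound 3 (0.28 log units; within the scatter), a 4.4-fold lower number from compound 2 to compound 3 (0.64 log units; beyond the scatter) and a 2.3-fold higher number from compound 1 to compound 2 (0.36 log units; beyond the scatter), so the three variants span a modest range. For the measured compounds named here, compound 4 `CS(=O)(=O)c1cnc(O[C@H]2CC[C@H](OC3CCN(C(=O)C4(C(F)(F)F)CCCC4)CC3)CC2)cn1` departs from compound 3 by a group of 9 heavy atoms (6 carbon, 3 fluorine; one five-membered non-aromatic ring of carbon only) in place of a group of 7 heavy atoms (6 carbon, 1 oxygen; one six-membered aromatic ring of carbon only), on a carbonyl carbon, which also removes the carbamate oxygen itself; no measured step covers that kind of change, so the precedent is weak. Compound 4 is therefore expected to show a step of a 2.2-fold higher number from compound 3 to compound 4 (0.35 log units; beyond the scatter), with wide uncertainty, giving an estimated 160 nM in this assay, between 45 nM and 600 nM.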

Compound 4, half-maximal effective concentration: 108 nM
Compound 4: middle estimate off by 1.5-fold (0.17 log units), on the high side, within the range that was stated.
By their numbers in this assay, from the lowest: compounds 3, 4 and 1 (each within the scatter of the next); then compound 2.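

The carbamate oxygen turns out not to be needed here: on the carbonyl carbon, the five-membered non-aromatic ring group without that oxygen gives a 1.5-fold higher number from compound 3 to compound 4 (0.18 log units; within the scatter) and a 1.3-fold lower number from compound 1 to compound 4 (0.11 log units; within the scatter), both within the scatter of the two best carbamates. Only compound 2 stands apart, with a 2.9-fold lower number from compound 2 to compound 4 (0.47 log units; beyond the scatter). Nothing available explains this tolerance.

Going by these compounds, it remains open how this assay would read with a methyl group in place of the trifluoromethyl on that ring. On these data alone, an amine nitrogen on the carbonyl carbon is equally open.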